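The source may hold more compounds than are shown below. What is called first, only, known or untested is meant among the compounds shown, and "the series" means these compounds.

Measured compounds:
- Compound 1, `COc1cc(Cc2nc3c(N)nc(F)nc3n2CCOC(C)C)cc(OC)c1OC`: 15800 nM
- Compound 2, `CC[C@H](C)Cn1c(Cc2cc(OC)c(OC)c(OC)c2)nc2c(N)nc(F)nc21`: 43700 nM

In a functional assay on MCF7 cells (Homo sapiens) for antiproliferative activity (a lower number here means a stronger inhibitor, a higher number a weaker inhibitor), compound 1 gives 15800 nM, and compound 2 gives 43700 nM. For the measured compounds named here, compound 2 thus stands at the higher of the two numbers, and the only step recorded is the one in a 2.8-fold higher number from compound 1 to compound 2 (0.44 log units; beyond the scatter), a modest move in the direction of a weaker inhibitor.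

Compound 3, `CCCCn1c(Cc2cc(OC)c(OC)c(OC)c2)nc2c(N)nc(F)nc21`, differs from compound 2 by hydrogen in place of methyl on a saturated chain carbon bound to two saturated chain carbons. Going by the values given here, no measured pair shows this exact change; the step from compound 1 to compound 2 concerns the same chain position but a different exchange, so it bears on the new step only loosely. Given that, the expected step in this assay is a 1.2-fold lower number from compound 2 to compound 3 (0.10 log units; within the scatter), a change not expected to go beyond the scatter. Compound 3 is therefore estimated at 35000 nM, with a range from 15000 nM to 90000 nM.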

Compound 3, half-maximal inhibitory concentration: 24000 nM
Compound 3: the middle estimate sits 1.5-fold (0.16 log units) above what was measured; the range from low to high includes it.
By their numbers in this assay, from the lowest: compounds 1, 3 and 2 (each within the scatter of the next, the first and the last beyond it).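

In this assay, dropping the methyl on the saturated chain carbon bound to two saturated chain carbons, the change from a 2-methylbutyl to a butyl chain, gives a 1.8-fold lower number from compound 2 to compound 3 (0.26 log units; within the scatter), so this branch has no effect that can be read here. Putting ethyl in place of isopropoxy gives a 1.5-fold higher number from compound 1 to compound 3 (0.18 log units; within the scatter), so the straight butyl chain of compound 3 cannot be told apart from the ether chain of compound 1 either. Compound 3 thus lies within the scatter of both neighbours, and the gap between compound 1 and compound 2 is the only difference at this position that goes beyond it.

No measurement bears on why these numbers fall as they do. The compounds shown leave open whether an amine or a longer chain at this position would shift the number beyond the scatter.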